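Swapping a para substituent on a weakly active pyrazoline series

The source may report more compounds than this note shows. Statements on the series, on what has been measured and on what is new or still open speak of the compounds shown alone.

Among the measured compounds shown here, compound 2 `COc1ccc(C2CC(c3ccccc3)=NN2c2nc(-c3ccc(Cl)cc3)c(C#N)c(=O)n2C)cc1` is, on the numbers so far, one of only two measured compounds, and in a functional assay on MCF7 cells (Homo sapiens) for antiproliferative activity, with a stated time of 72 h (a higher number here means a weaker inhibitor, a lower number a stronger inhibitor), compound 2 gives 52400 nM. For the measured compounds named here, its only neighbour is compound 1 `Cn1c(N2N=C(c3ccccc3)CC2c2ccc(Cl)cc2)nc(-c2ccc(Cl)cc2)c(C#N)c1=O`, which in this assay gives 46300 nM; the step of a 1.1-fold higher number from compound 1 to compound 2 (0.05 log units; within the scatter) shows that exchanging chloro for methoxy at this position made no difference that the assay can resolve.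

The new compound 3 `Cn1c(N2N=C(c3ccccc3)CC2c2ccc(F)cc2)nc(-c2ccc(Cl)cc2)c(C#N)c1=O` differs from compound 2 in one place: fluoro in place of methoxy on an aromatic carbon. Going by the values given here, the one measured step that touches the same aromatic carbon is a 1.1-fold higher number from compound 1 to compound 2 (0.05 log units; within the scatter), and it stayed within the scatter. Among the compounds with values here, no step involving fluoro has been measured, so there is no direct precedent for this substituent.

Given that the only comparable exchange at this position left the number essentially unchanged, compound 3 is expected to stay in the same weakly active range, with the step of a 1.2-fold lower number from compound 2 to compound 3 (0.07 log units; within the scatter) estimated as no more than the scatter. The estimate for compound 3 in this assay is therefore 45000 nM, with a likely range from 20000 nM to 100000 nM.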

Compound 3, half-maximal inhibitory concentration: 36800 nM
Beside the measured number, compound 3's estimate is 1.2-fold (0.09 log units) above it; measured number inside the range.
By their numbers in this assay, from the lowest: compounds 3, 1 and 2 (each within the scatter of the next).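

With fluoro in this place, the phenyl ring has now carried three different groups, and this assay cannot tell them apart. Fluoro against methoxy gives a step within the scatter (a 1.4-fold lower number from compound 2 to compound 3 (0.15 log units; within the scatter)), and fluoro against chloro does too (a 1.3-fold lower number from compound 1 to compound 3 (0.10 log units; within the scatter)). The earlier pair covered only chloro and methoxy, so the flat reading now extends to a third group, and to a swap of two heavy atoms for one, while the numbers all stay in the same weak range. No supporting data are available to explain why these exchanges leave the number unresolved.

Going by these compounds, all three groups are small single substituents in one place, so it remains open whether an amine, a carboxylic acid or a longer chain such as butoxy there would shift the number beyond the scatter, or whether this place simply has little influence on the antiproliferative reading. Also open, on these data alone, is whether a change elsewhere on the shared core would do more than any exchange at this position has done so far.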